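The source may report more compounds than this note shows. Statements on the series, on what has been measured and on what is new or still open speak of the compounds shown alone.

Compound 1 `CCCCNc1nc(NCc2ccco2)c2ccccc2n1` was tested in a functional assay on HCT-116 cells (Homo sapiens) for cytotoxicity, read by MTT assay, with a stated time of 2 days, tested at 10 uM (on this read-out lower numbers stand for less inhibition and higher numbers for more inhibition at the one concentration tested (going by the name of the read-out)), where compound 1 gives 94.8%, second highest of three numbers. Its neighbours are compound 2 `Cc1cccc(N2CCN(CCCNc3nc(NCc4ccco4)c4ccccc4n3)CC2)c1C`, which gives 93.2%, and compound 3 `Cc1cccc(N2CCN(CCCNc3nc(NCc4ccco4)c4cc(F)ccc4n3)CC2)c1C`, which gives 97.3%; both differences from compound 1 lie within the scatter. Going by the values given here, the only single-point step measured, a number 4.1 percentage points higher from compound 2 to compound 3 (within the scatter), also stays within the scatter.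

Compound 4 `CCN(CC)CCNc1nc(NCc2ccco2)c2ccccc2n1` differs from compound 1 by diethylamino in place of ethyl on a saturated chain carbon, two bonds along the chain from a nitrogen on an aromatic ring. Among the compounds with values here, no measured step touches this chain, so the one step known offers no direct guide; with all three numbers this high and this close, the expectation for compound 4 is a number 2.8 percentage points lower from compound 1 to compound 4 (within the scatter), essentially no step beyond the scatter. Compound 4 is therefore estimated at 92%, within 78% to 99%.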

Compound 4, a percentage reported as inhibition, at one concentration (the size of the read-out at that concentration, not a potency): 50.3%
Compound 4: middle estimate off by 41.7 percentage points, on the high side; the measured number lies below the stated range.
By their numbers in this assay, from the lowest: compound 4; then compounds 2, 1 and 3 (each within the scatter of the next).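

In this assay this chain position proves sensitive: diethylamino in place of ethyl gives a number 44.5 percentage points lower from compound 1 to compound 4 (beyond the scatter) and so a large step, which the closely grouped earlier compounds gave no sign of. The entering group carries a nitrogen and a hydrogen-bond acceptor that ethyl lacks, and it is larger, but nothing available explains the drop. As far as these compounds go, whether the nitrogen matters or the size alone stays open. A plain hexyl chain, which has no nitrogen, or a smaller dimethylamino group in the same place would help separate the two.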